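Removing the ring fluorine: what to expect for compound 4

The source may hold more compounds than are shown below. What is called first, only, known or untested is meant among the compounds shown, and "the series" means these compounds.

A small set of naphthyl sugar-like compounds was tested in a functional assay on HCC70 cells (Homo sapiens) for antiproliferative activity, read by crystal violet staining, with a stated time of 96 h; a lower number here means that less compound is needed, a higher number that more compound is needed for the effect. Compound 1 `O[C@@H]1[C@@H](O)[C@H](Oc2ccc3ccccc3c2)OC[C@H]1O` has been measured repeatedly and gives 91 uM; 363 uM (2 entries), two entries that lie far apart, as shown by the several entries of compound 1 in this assay, 91 uM; 363 uM (2 entries). Compound 2 `CO[C@@H]1[C@@H](O)[C@H](Oc2ccc3ccccc3c2)OC[C@H]1O` gives 145 uM in this assay. Compound 3 `O[C@H]1[C@H](Oc2ccc3ccccc3c2)OC[C@@H](O)[C@@H]1F` gives 94 uM in this assay. Going by the values given here, compound 3 and compound 2 sit within the scatter of each other, and the two entries of compound 1 straddle them, so no compound here stands apart from the rest.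

Among the compounds with values here, the only single-point step so far, a 1.5-fold lower number from compound 2 to compound 3 (0.19 log units; within the scatter), replaced methoxy with fluoro on a saturated ring carbon and moved the number by less than the scatter. Compound 4 `O[C@@H]1CO[C@@H](Oc2ccc3ccccc3c2)[C@H](O)C1` takes one more step in the same region: hydrogen in place of fluoro on a saturated ring carbon. Since the earlier change at this position, a 1.5-fold lower number from compound 2 to compound 3 (0.19 log units; within the scatter), did nothing measurable, the expected step for compound 4 is small as well, a 1.3-fold higher number from compound 3 to compound 4 (0.11 log units; within the scatter). Compound 4 is therefore estimated at 120 uM in this assay, with a plausible range from 45 uM to 350 uM.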

Compound 4, concentration for half-maximal effect: 179 uM
Compound 4: the middle estimate sits 1.5-fold (0.17 log units) below what was measured, within the range that was stated.
By their numbers in this assay, from the lowest: compounds 3, 2 and 4 (each within the scatter of the next).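

Compound 4 shows what happens when this ring carbon carries no group other than hydrogen, which neither compound 2 nor compound 3 could show. In this assay, the result is a 1.9-fold higher number from compound 3 to compound 4 (0.28 log units; within the scatter), and also a 1.2-fold higher number from compound 2 to compound 4 (0.09 log units; within the scatter). Among compounds 2, 3 and 4, then, fluoro, methoxy and hydrogen on this saturated ring carbon, next to two ring atoms that each bear a hydroxy group, cannot be told apart, and the repeat entries of compound 1 lie further apart than any of these three numbers, so a small real effect would be hard to see: the several entries of compound 1 in this assay, 91 uM; 363 uM (2 entries)

Still open, going by these compounds, is whether an amine or a carboxylic acid on this ring carbon would move the number beyond the scatter. On these data alone, a longer chain in place of methoxy remains an equally open case.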